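Extending the acyl group on the ring nitrogen of compound 1

The compounds below may be only part of what the source reports. "The series", "measured", "known", "first", "only" and "open" are said of these compounds alone.

Compound 1 `Nc1nc(CN=C=S)cs1` was tested in a functional assay on L1210 cells (Mus musculus) for antiproliferative activity (on this read-out higher numbers stand for weaker inhibition and lower numbers for stronger inhibition), and gave 26000 nM. Among the two compounds measured so far, compound 1 has the highest number, and its nearest neighbour is compound 2 `CC(=O)Nc1nc(CN=C=S)cs1`, which in this assay gave 5200 nM. For the measured compounds named here, the single measured step between them, a 5.0-fold lower number from compound 1 to compound 2 (0.70 log units; beyond the scatter), shows what happens when an acetyl group is placed on the nitrogen attached to the shared core: the number fell by a modest amount that lies beyond the usual scatter.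

Compound 3 `CC(C)C(=O)Nc1nc(CN=C=S)cs1` has not yet been measured. It differs from compound 1 in one place: isopropylcarbonyl in place of hydrogen on a nitrogen on an aromatic ring. Going by the values given here, this change is of the same kind as the acetyl step, only with a larger acyl group, so the step from compound 1 to compound 2 is the only measured step that bears on it. On that basis a step of similar size and in the same direction, toward a lower number, is expected, a 5.2-fold lower number from compound 1 to compound 3 (0.72 log units; beyond the scatter). For compound 3 the estimated value in this assay is 5000 nM, with a range from 1500 nM to 16000 nM.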

Compound 3, half-maximal inhibitory concentration: 8200 nM
For compound 3 the middle estimate is 1.6-fold (0.21 log units) below the measured one; the range from low to high includes it.
By their numbers in this assay, from the lowest: compounds 2 and 3 (each within the scatter of the next); then compound 1.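

A second acyl group on the nitrogen of the shared core also lowers the number: in this assay there is a 3.2-fold lower number from compound 1 to compound 3 (0.50 log units; beyond the scatter) when isopropylcarbonyl replaces hydrogen, so the drop seen with acetyl is not unique to that one group. Comparing the two acylated compounds directly, replacing methyl with isopropyl on the carbonyl carbon gives a 1.6-fold higher number from compound 2 to compound 3 (0.20 log units; within the scatter) and this lies within the scatter, so this assay does not separate compound 2 from compound 3, and enlarging the acyl group to isopropylcarbonyl brings no measurable gain or loss. Nothing available here explains why placing an acyl group on this nitrogen lowers the number.

The compounds shown leave open whether the result would hold for a longer straight chain on the carbonyl carbon, or for a benzoyl group, which would bring in a ring. They also leave open whether the carbonyl itself matters, since a simple methyl group on this nitrogen, with no carbonyl, is not among them.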